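From 4-chlorophenyl to 2-iodophenyl on the sulfonyl sulfur

The source may hold more compounds than are shown below. What is called first, only, known or untested is meant among the compounds shown, and "the series" means these compounds.

In a functional assay on SGC-7901 cells (Homo sapiens) for antiproliferative activity, read by MTT assay, with a stated time of 48 h (a higher number here means that more compound is needed for the effect, a lower number that less compound is needed), compound 1 `CC1=NN(S(=O)(=O)c2ccccc2)C(c2cc(Br)ccc2O)C1` gives 55600 nM. Compound 2 `CC1=NN(S(=O)(=O)c2ccc(Cl)cc2)C(c2cc(Br)ccc2O)C1` gives > 60000 nM, which is a limit of the assay and not a number. Compound 2 therefore has no exact place on the scale, only (the limit of > 60000 nM in this assay, at which 1 of the 2 values shown sits).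

The next structure, compound 3 `CC1=NN(S(=O)(=O)c2ccccc2I)C(c2cc(Br)ccc2O)C1`, keeps the shared core and alters one group: 2-iodophenyl in place of 4-chlorophenyl on a sulfonyl sulfur. In words, 2-iodophenyl stands in place of 4-chlorophenyl on a sulfonyl sulfur. Within the data shown here, only one measured step bears on this, and it is a thin guide. Chloro in place of hydrogen on an aromatic carbon gave an at least 1.0-fold higher number from compound 1 to compound 2 (0.03 log units; that floor lies within the scatter). Among the measured compounds shown here, that floor shows no shift beyond the scatter, and no measured compound carries iodine. For the measured compounds named here, the only true number to lean on is that of compound 1, at 55600 nM. The expected change is therefore an at least 1.0-fold lower number from compound 2 to compound 3 (0.03 log units; that floor lies within the scatter), which is estimated to be no step beyond the scatter in either direction. For compound 3 the expected value is 55000 nM, with an estimated range from 20000 nM to 100000 nM.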

Compound 3, half-maximal effective concentration: > 60000 nM
Compound 3 was reported as a limit (the forecaster's own chance of this, stated with the estimate: 45%); middle value at least 1.0-fold (0.03 log units) away from the limit.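

Replacing 4-chlorophenyl with 2-iodophenyl on the sulfonyl sulfur leaves the compound at the end of the readable scale, so a second halogen-bearing ring now joins compound 2 there: the limit of > 60000 nM in this assay, at which 2 of the 3 values shown sit.

Adding iodine to the ring on the sulfonyl sulfur gives an at least 1.0-fold higher number from compound 1 to compound 3 (0.03 log units; that floor lies within the scatter), so neither the iodine nor the earlier chlorine has brought the number down in this assay, and the floor of each step shows no shift beyond the scatter. The step between the two limits cannot be read, which means that 4-chlorophenyl and 2-iodophenyl cannot be ranked against each other.

The compounds shown leave open whether any other group on the sulfonyl sulfur, such as a phenyl ring bearing an amine, a carboxylic acid or a methoxy group, could bring the number well below that of compound 1. They also leave open how far past the limit compound 2 and compound 3 truly lie, and whether the kind of halogen or its place on the ring matters more, as these two compounds differ in both.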